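This account rests on a few compounds, and the source may have more. Where it says the series, first, only, none or still open, it means among the compounds named here.

Compound 1 `CCCOC(=O)C1=C(C)NC(=S)NC1c1ccco1`, measured in an assay on membranes from HeLa cells for displacement of a labelled ligand from adenosine receptor A3 (Homo sapiens), read by scintillation counting, with a stated time of 180 min, tested at 1 uM (on this read-out higher numbers stand for more inhibition at the one concentration tested (going by the name of the read-out) and lower numbers for less inhibition), gives 1%. Compound 2 `CC1=C(C(=O)OC(C)(C)C)C(c2ccco2)NC(=S)N1` gives 9% in this assay; the step of a number 8 percentage points higher from compound 1 to compound 2 (within the scatter) is recorded as within the scatter. Going by the values given here, compound 2 therefore stands at one of only two numbers so far, and its number and that of compound 1 cannot be told apart beyond the scatter of such measurements.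

Compound 3 `CC1=C(C(=O)OCc2ccccc2)C(c2ccco2)NC(=S)N1` carries the change (benzyl in place of tert-butyl on an oxygen next to a carbonyl group). Among the compounds with values here, the only measured step that bears on it is the earlier exchange of one group on the same oxygen, a number 8 percentage points higher from compound 1 to compound 2 (within the scatter), which was small and within the scatter. On that basis no step beyond the scatter is expected for compound 3, and the estimated step is a number 1 percentage points higher from compound 2 to compound 3 (within the scatter). Compound 3 is thus expected to give about 10% in this assay, with a likely range from -5% to 25%.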

Compound 3, a percentage reported as inhibition, at one concentration (the size of the read-out at that concentration, not a potency): 4%
Beside the measured number, compound 3's estimate is 6 percentage points above it; the measured number falls inside the stated range.
By their numbers in this assay, from the lowest: compounds 1, 3 and 2 (each within the scatter of the next).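

With benzyl in place of tert-butyl on the oxygen next to a carbonyl group, this assay shows a number 5 percentage points lower from compound 2 to compound 3 (within the scatter) and, set against the propyl group of compound 1, a number 3 percentage points higher from compound 1 to compound 3 (within the scatter) as well. The earlier compounds shown here carried no ring at this place, and the six-membered aromatic ring of benzyl does not set compound 3 apart, since compounds 1, 2 and 3 all lie within the scatter of one another. Nothing available explains this result. As far as these compounds go, whether a chain ending in an amine or a carboxylic acid on this oxygen would move the number beyond the scatter remains open. Also open, from the compounds shown here alone, is whether a change elsewhere on the shared core would do so, and these single-concentration numbers give no potency for any of the three compounds.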